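A few compounds are considered here, and "the series" means these few. Any claim that something is new, unique, unknown or untested is made for them only; others in the source may bear on it.

Measured so far in a functional assay on HEK293 cells for agonist activity at Bombesin receptor subtype-3 (Mus musculus), read by luminescence and calcium flux, with a stated time of 10 min; on this read-out lower numbers stand for an effect already at smaller amounts and higher numbers for an effect only at larger amounts of compound:
compound 1 `CCC(C)(C)Cc1c[nH]c(CCc2ccc(-c3ccncc3)cc2)n1` gives 103 nM;
compound 2 `CCC(C)(C)Cc1c[nH]c(CCc2ccc(-n3ncnn3)cc2)n1` gives 99 nM;
compound 3 `CCC(C)(C)Cc1c[nH]c(CCc2ccc(-c3ccc(F)cn3)cc2)n1` gives 105 nM.

Compound 3 holds the highest of these three numbers, though only by steps within the scatter: a 1.0-fold higher number from compound 1 to compound 3 (0.01 log units; within the scatter) and a 1.1-fold higher number from compound 2 to compound 3 (0.03 log units; within the scatter). The remaining step, a 1.0-fold lower number from compound 1 to compound 2 (0.02 log units; within the scatter), is just as flat. Compound 4 `CCC(C)(C)Cc1c[nH]c(CCc2ccc(-c3cnsc3)cc2)n1` carries 1,2-thiazol-4-yl in place of 5-fluoropyridin-2-yl on an aromatic carbon. All three measured steps exchange the ring at this same place on the shared core, and none of them moved the number beyond the scatter, so they bear directly on this change. For compound 4, the expected step in this assay is a 1.1-fold lower number from compound 3 to compound 4 (0.02 log units; within the scatter), a flat one. Compound 4 is therefore estimated at 100 nM, with a range from 50 nM to 200 nM.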

Compound 4, half-maximal effective concentration: 119 nM
Estimate against measurement, compound 4: 1.2-fold (0.08 log units) below; the measured number falls inside the stated range.
By their numbers in this assay, from the lowest: compounds 2, 1, 3 and 4 (each within the scatter of the next).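

In this assay, a sulfur-containing ring at this place gives no step beyond the scatter: a 1.1-fold higher number from compound 3 to compound 4 (0.05 log units; within the scatter), a 1.2-fold higher number from compound 1 to compound 4 (0.06 log units; within the scatter) and a 1.2-fold higher number from compound 2 to compound 4 (0.08 log units; within the scatter). The flat picture thus extends to 1,2-thiazol-4-yl, a five-membered aromatic ring with fewer heavy atoms than 5-fluoropyridin-2-yl, so all four rings tried here read alike. No measurement at hand explains why these exchanges leave the number so flat. From the compounds shown here alone, whether this holds for a non-aromatic group here, such as an amine, a carboxylic acid or a morpholine ring, remains open.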